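Cyano for cyanoethenyl: expected tolerance of compound 3

The source may hold more compounds than are shown below. What is called first, only, known or untested is meant among the compounds shown, and "the series" means these compounds.

In an ADME assay on MT4 cells (Homo sapiens) for cytotoxicity, read by MTT assay, with a stated time of 5 days (a higher number here means that more compound is tolerated, a lower number that less compound is tolerated), compound 1 `Cc1cc(C#N)cc(C)c1Oc1ccnc(NCCn2ccc(=O)[nH]c2=O)n1` gives 35800 nM. Compound 2 `Cc1cc(/C=C/C#N)cc(C)c1Oc1nc(NCCn2ccc(=O)[nH]c2=O)ncc1Cl` reaches only a limit in this assay, > 284000 nM. Compound 2 therefore stands at the limit of > 284000 nM in this assay, at which 1 of the 2 values shown sits, and its tolerated concentration is not known beyond that bound. Compound 3 `Cc1cc(C#N)cc(C)c1Oc1nc(NCCn2ccc(=O)[nH]c2=O)ncc1Cl` is the next member of the series: cyano in place of 2-cyanoethenyl on an aromatic carbon. Among the measured compounds shown here, no measured pair carries this change, so the step has to be judged from the two values at hand. Compound 1 carries the same cyano group on its own core and gives 35800 nM, a number rather than a limit. The step from compound 2 to compound 3 is expected to lower the tolerated concentration, an at least 3.1-fold lower number from compound 2 to compound 3 (0.49 log units; beyond the scatter), beyond the scatter of this assay. Compound 3 is estimated at 90000 nM, with a range from 30000 nM to 284000 nM.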

Compound 3, half-maximal cytotoxic concentration: > 11600 nM
Compound 3 was reported as a limit (the forecaster's own chance of this, stated with the estimate: 35%); the middle value is on the limit's open side.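

In this assay, among the compounds shown here, compound 3 gives > 11600 nM as a limit, so no step to compound 3 from compound 1 or compound 2 can be read. The compounds shown leave open how cyano in place of 2-cyanoethenyl, or chloro in place of hydrogen, changes the tolerated concentration.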